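Replacing 3,4-dimethoxyphenyl in the compound 3 series

The compounds below may be only part of what the source reports. "The series", "measured", "known", "first", "only" and "open" are said of these compounds alone.

In a functional assay on HepG2 cells (Homo sapiens) for antiproliferative activity, read by sulforhodamine B assay, with a stated time of 48 h (a higher number here means a weaker inhibitor, a lower number a stronger inhibitor), compound 1 (`COc1cccc(/C=C/C(=O)/C=C(O)/C=C/c2cccc(OC)c2OC)c1OC`) gives 12900 nM and compound 2 (`COc1ccc(OC)c(/C=C/C(=O)/C=C(O)/C=C/c2cc(OC)ccc2OC)c1`) gives 5560 nM. Compound 3 (`COc1ccc(C=C(C(=O)/C=C/c2cccc(OC)c2OC)C(=O)/C=C/c2cccc(OC)c2OC)cc1OC`) gives 200 nM, the lowest of the three numbers and beyond the scatter from both of the others. Still unmeasured, compound 4 (`COc1cccc(/C=C/C(=O)C(=Cc2ccc(O)c(F)c2)C(=O)/C=C/c2cccc(OC)c2OC)c1OC`) carries 3-fluoro-4-hydroxyphenyl in place of 3,4-dimethoxyphenyl on a double-bonded chain carbon bound to a double-bonded chain carbon. Going by the values given here, no two measured compounds differ in only one place, so the data offer no direct guide to the size of this change. The expectation therefore starts from compound 3 at 200 nM, and only a modest rise is expected in this assay, possibly none beyond the scatter. The expected step is a 1.4-fold higher number from compound 3 to compound 4 (0.15 log units; within the scatter). For compound 4 the estimated value is 280 nM, with an expected range from 80 nM to 1000 nM.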

Compound 4, half-maximal inhibitory concentration: 220 nM
Compound 4: middle estimate off by 1.3-fold (0.10 log units), on the high side; the range from low to high includes it.
By their numbers in this assay, from the lowest: compounds 3 and 4 (each within the scatter of the next); then compound 2; then compound 1.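

In this assay, compound 3 and compound 4 form the first pair shown that differ in only one place, and the step is a 1.1-fold higher number from compound 3 to compound 4 (0.04 log units; within the scatter). On a double-bonded chain carbon bound to a double-bonded chain carbon, 3-fluoro-4-hydroxyphenyl and 3,4-dimethoxyphenyl therefore cannot be told apart in this read-out, although the entering group has 1 hydrogen-bond donor and the leaving group has 0. Nothing available here accounts for this result.

The hydroxy group and the fluorine enter together, so the compounds shown do not separate what each contributes at this position. They also leave open how the position would read with a phenyl carrying an amine or a carboxylic acid.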